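From Hydroxypropyl to Ethoxycarbonyl on a Shared Core

This account rests on a few compounds, and the source may have more. Where it says the series, first, only, none or still open, it means among the compounds named here.

Measured in an ADME assay on PANC-1 cells (Homo sapiens) for cytotoxicity, read by sulforhodamine B assay, with a stated time of 48 h, tested at 10 uM; a lower number here means less inhibition, a higher number more inhibition at the concentration tested (going by the name of the read-out):
Compound 1, `COc1nc2ccc(Br)cc2cc1C(c1ccccc1)n1cc(-c2ccccc2F)nn1`: 14.7%
Compound 2, `COc1nc2ccc(Br)cc2cc1C(c1ccccc1)n1cc(-c2cccc(F)c2)nn1`: 15.5%
Compound 3, `COc1nc2ccc(Br)cc2cc1C(c1ccccc1)n1cc(CCCO)nn1`: 25.5%

Among the compounds with values here, compound 3 stands highest of the three numbers, but its lead is thin: the gap from compound 2 is within the scatter, and only the step of a number 10.8 percentage points higher from compound 1 to compound 3 (beyond the scatter) clears it, and modestly so. Compound 1 and compound 2, which differ only in the position of a fluorine on the phenyl, are indistinguishable, as the step of a number 0.8 percentage points higher from compound 1 to compound 2 (within the scatter) shows.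

Compound 4, `CCOC(=O)c1cn(C(c2ccccc2)c2cc3cc(Br)ccc3nc2OC)nn1`, is not yet measured. Relative to compound 3 the change is ethoxycarbonyl in place of 3-hydroxypropyl on an aromatic carbon.

Within the data shown here, no measured step covers this exchange; the steps of a number 10 percentage points higher from compound 2 to compound 3 (within the scatter) and a number 10.8 percentage points higher from compound 1 to compound 3 (beyond the scatter) concern the arrival of the hydroxypropyl from an aryl, not its replacement by an ester. All three measured steps are small, the largest only modest, so a step of similar or smaller size is the reasonable expectation, with no direction preferred. Compound 4 is therefore expected to give about 18% in this assay , between 6% and 32%. That estimate implies an expected step of a number 7.5 percentage points lower from compound 3 to compound 4 (within the scatter), which lies within the scatter.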

Compound 4, a percentage reported as inhibition, at one concentration (the size of the read-out at that concentration, not a potency): 15.4%
The estimate for compound 4 lay 2.6 percentage points above the measured number; the range from low to high includes it.
By their numbers in this assay, from the lowest: compounds 1, 4, 2 and 3 (each within the scatter of the next, the first and the last beyond it).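

In this assay this position on the five-membered aromatic ring with 3 nitrogen now shows a limited response to a change between two ring-free groups: ethoxycarbonyl in place of 3-hydroxypropyl gives a number 10.1 percentage points lower from compound 3 to compound 4 (beyond the scatter). Ethoxycarbonyl also cannot be told apart from either fluorophenyl group, with a number 0.1 percentage points lower from compound 2 to compound 4 (within the scatter) and a number 0.7 percentage points higher from compound 1 to compound 4 (within the scatter), so among these compounds an aryl ring at this position is not required for a reading of this size. The exchange at this position also takes away the hydrogen-bond donor counted on 3-hydroxypropyl and brings a second hydrogen-bond acceptor, but nothing available links either count, or any other feature of the two groups, to the difference in the readings.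

The compounds shown leave open whether the hydroxyl, the three-carbon chain or both set 3-hydroxypropyl apart, a question that a plain propyl chain, a longer hydroxyalkyl chain or a primary amine at the same position could address. On these data alone, it is equally open how a carboxylic acid or a primary amide would compare with ethoxycarbonyl there.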